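Compound 3: a thiazole replaces the fluorophenyl

A few compounds are considered here, and "the series" means these few. Any claim that something is new, unique, unknown or untested is made for them only; others in the source may bear on it.

Compounds measured in a functional assay on HOS-TE85 cells (Homo sapiens) for inhibition, read by CCK-8 assay, with a stated time of 72 h; a higher number here means a weaker inhibitor, a lower number a stronger inhibitor:
- compound 1 `CC(C)(C)c1conc1N1C(=O)CSC1c1cccc(C(=O)NCCCCc2ccccc2)c1`: > 1000 nM (a limit)
- compound 2 `O=C(NCCCCc1ccccc1)c1cccc(C2SCC(=O)N2c2ccccc2F)c1`: 34.1 nM

Among the measured compounds shown here, compound 2 holds the only true number in this assay, at 34.1 nM. Compound 1 gives > 1000 nM, which is a limit of the assay and not a number. For the measured compounds named here, the one measured step, an at least 29-fold lower number from compound 1 to compound 2 (1.46 log units; beyond the scatter), is large and beyond the scatter, and it changes the group on the same amide-type nitrogen in a ring.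

Compound 3 `O=C(NCCCCc1ccccc1)c1cccc(C2SCC(=O)N2c2nccs2)c1` has not yet been measured. It carries 1,3-thiazol-2-yl in place of 2-fluorophenyl on an amide-type nitrogen in a ring. The group that enters is, like the group on compound 1, a five-membered aromatic ring with 2 hetero atoms, although the two groups are not the same. Going by the values given here, with an at least 29-fold lower number from compound 1 to compound 2 (1.46 log units; beyond the scatter) as the only guide, a sizeable move to a higher number is expected, though perhaps not all the way to the limit. The expected change is a 5.9-fold higher number from compound 2 to compound 3 (0.77 log units; beyond the scatter). For compound 3 the estimated value is 200 nM, with an expected range from 50 nM to 900 nM.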

Compound 3, half-maximal inhibitory concentration: > 1000 nM
Compound 3 gave a limit, no number; the forecaster's own chance of this, stated with the estimate: 20%; middle value at least 5.0-fold (0.69 log units) away from the limit.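

In this assay, 1,3-thiazol-2-yl in place of 2-fluorophenyl on the amide-type nitrogen gives an at least 29-fold higher number from compound 2 to compound 3 (1.46 log units; beyond the scatter), so this group here goes with a loss as large as the one seen with the larger group on compound 1, and the size of the incoming group alone does not sort these compounds. The value of compound 3, > 1000 nM, is a limit of the assay and not a number. Among the three compounds, only 2-fluorophenyl gives a readable value at this position, while the two five-membered aromatic rings with 2 hetero atoms cannot be ranked against each other because the step between them is unreadable: the limit of > 1000 nM in this assay, at which 2 of the 3 values shown sit.

The compounds shown leave open whether the fluorine of compound 2 matters, which plain phenyl or 2-chlorophenyl on the same nitrogen would address. They also leave open whether a six-membered ring with a ring nitrogen, such as pyridin-2-yl, would keep a readable value in this assay or join compound 1 and compound 3 at the limit.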